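This account rests on a few compounds, and the source may have more. Where it says the series, first, only, none or still open, it means among the compounds named here.

Measured so far in a functional assay on A549 cells (Homo sapiens), read by MTT assay, with a stated time of 72 h; a higher number here means a weaker inhibitor, a lower number a stronger inhibitor
- compound 1 `C#Cc1cn([C@@H]2O[C@H](CO)[C@@H](O)[C@H]2O)c2ncnc(OC)c12` gives 8160 nM
- compound 2 `CNc1ncnc2c1c(-c1cccs1)cn2[C@@H]1O[C@H](CO)[C@@H](O)[C@H]1O` gives > 20000 nM as a limit
- compound 3 `CNc1ncnc2c1c(-c1ccccc1)cn2[C@@H]1O[C@H](CO)[C@@H](O)[C@H]1O` gives > 20000 nM as a limit

Compound 3 has only a limit (> 20000 nM) and no number. From the compounds shown here alone, it therefore sits with compound 2 at one shared mark (the limit of > 20000 nM in this assay, at which 2 of the 3 values shown sit), so its true distance from any other compound is unknown.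

Compound 4 `C#Cc1cn([C@@H]2O[C@H](CO)[C@@H](O)[C@H]2O)c2ncnc(NC)c12` keeps the core of compound 3 and puts ethynyl in place of phenyl on an aromatic carbon, on the five-membered aromatic ring ethynyl in place of phenyl on an aromatic carbon and nothing else changes.

Going by the values given here, the one measured step is a step that the two limits leave unreadable from compound 2 to compound 3 and it exchanges one aromatic group for another, so it offers no size to carry over. Among the compounds with values here, the only real number comes from compound 1 (8160 nM), which also carries ethynyl but differs from compound 4 elsewhere on the core. That value is the sole hint that an ethynyl compound can register under the limit, so a move towards stronger inhibition in this assay is expected, though compound 4 could still end up reported as a limit. The expected step, a rough estimate only, is an at least 2.8-fold lower number from compound 3 to compound 4 (0.45 log units; beyond the scatter) and its size is uncertain. Compound 4 is estimated at 7000 nM (expected range 1200 nM to 20000 nM).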

Compound 4, half-maximal inhibitory concentration: > 20000 nM
Compound 4: no number, only a limit; the forecaster's own chance of this, stated with the estimate: 35%; middle value at least 2.8-fold (0.45 log units) from the limit.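

In this assay, compound 4 is reported only as a limit, > 20000 nM. Going by these compounds alone, its pair with compound 1 gives the first step of readable size in this set: methylamino in place of methoxy on an aromatic carbon, with ethynyl kept on the five-membered ring, gives an at least 2.4-fold higher number from compound 1 to compound 4 (0.38 log units; beyond the scatter), so ethynyl at this place does not by itself bring a compound under the limit. The steps to ethynyl from phenyl and from thiophen-2-yl cannot be read, and all three compounds with methylamino now share one mark, so no order among these groups can be drawn: the limit of > 20000 nM in this assay, at which 3 of the 4 values shown sit.

From the compounds shown here alone, it remains open whether any group at this place of the five-membered ring, such as a nitrile or an ethyl chain, would give a measurable number while methylamino stays on the core. Going by these compounds, it is equally open whether a plain amine in place of methylamino would behave like methoxy or like methylamino, and whether phenyl or thiophen-2-yl would give a number with methoxy on the core.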